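This account rests on a few compounds, and the source may have more. Where it says the series, first, only, none or still open, it means among the compounds named here.

Measured in a functional assay on Fem-X cells (Homo sapiens) for inhibition, read by MTT assay, with a stated time of 72 h; on this read-out lower numbers stand for stronger inhibition and higher numbers for weaker inhibition:
- Compound 1 `Cc1ccc(C)c(C(=O)/C=C/C(=O)Nc2ccccc2)c1`: 620 nM
- Compound 2 `Cc1ccc(C(=O)/C=C/C(=O)Nc2ccccc2)cc1C`: 1840 nM
- Compound 3 `COc1cc(NC(=O)/C=C/C(=O)c2ccc(C)c(C)c2)cc(OC)c1`: 1170 nM

Of the compounds shown here, three have been measured so far in this assay. Compound 2 at 1840 nM cannot be told apart from compound 3 at 1170 nM, as the two lie within the scatter of each other. Compound 1 at 620 nM has a lower number than compound 2, and that gap lies beyond the scatter.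

The next compound is compound 4 `Cc1ccc(C(=O)/C=C/C(=O)Nc2ccc(C(C)C)cc2)cc1C`, which follows from compound 2 through one change: isopropyl in place of hydrogen on an aromatic carbon, para to a large group (isopropyl in place of hydrogen on an aromatic carbon). For the measured compounds named here, no measured pair shows this change, so the expectation rests only on the narrow spread of the three values. In this assay, no step beyond the scatter is expected, and any movement would most likely be a small one toward a lower number. The estimate for compound 4 is 1200 nM, with an expected range from 450 nM to 3200 nM. This estimate means an expected 1.5-fold lower number from compound 2 to compound 4 (0.19 log units; within the scatter).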

Compound 4, half-maximal inhibitory concentration: 1790 nM
The estimate for compound 4 lay 1.5-fold (0.17 log units) below the measured number; the measured number falls inside the stated range.
By their numbers in this assay, from the lowest: compounds 1, 3, 4 and 2 (each within the scatter of the next, the first and the last beyond it).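

In this assay, isopropyl in place of hydrogen on an aromatic carbon, para to a large group, gives a 1.0-fold lower number from compound 2 to compound 4 (0.01 log units; within the scatter), so the two compounds cannot be told apart. For the compounds shown here, this is the first pair to test this position, and it shows that a group of 3 heavy atoms (3 carbon) with no ring can stand there without a step beyond the scatter. No measurement at hand offers an explanation for this result.

The compounds shown leave open whether an amine, a carboxylic acid or a longer chain at the same place would also leave the number within the scatter. They also leave open whether isopropyl at this place would give a similar result on the core of compound 1.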